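This account rests on a few compounds, and the source may have more. Where it says the series, first, only, none or still open, it means among the compounds named here.

Compound 1 `NC(N)=NC(=O)c1ncc(-c2ccccc2)nc1N` serves as the starting point. In an assay for inhibition of acid-sensing ion channel 3 (Homo sapiens), read by patch clamp, tested at 1 uM (a lower number here means less inhibition, a higher number more inhibition at the concentration tested (going by the name of the read-out)), compound 1 gives 35%, the highest of the three numbers measured. Compound 2 `NC(N)=NC(=O)c1ncc(-c2ccsc2)nc1N` gives 23%, and compound 3 `NC(N)=NC(=O)c1ncc(-c2ccccc2-c2ccccc2)nc1N` gives 8%. Both changes away from compound 1 lowered the read-out: a number 12 percentage points lower from compound 1 to compound 2 (beyond the scatter) and a number 27 percentage points lower from compound 1 to compound 3 (beyond the scatter).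

Compound 4 `NC(N)=NC(=O)c1ncc(-c2cccc(-c3ccoc3)c2)nc1N` differs from compound 1 in one place: furan-3-yl in place of hydrogen on an aromatic carbon. The step that bears on it is the addition of phenyl in place of hydrogen on an aromatic carbon in compound 3, which lowered the read-out by a modest amount. An added aromatic ring, here a smaller five-membered one, is therefore expected to lower the number again, by a number 17 percentage points lower from compound 1 to compound 4 (beyond the scatter). Compound 4 is estimated to give 18%, within a range of 5% to 32%.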

Compound 4, a percentage reported as inhibition, at one concentration (the size of the read-out at that concentration, not a potency): 30%
Compound 4: middle estimate off by 12 percentage points, on the low side, within the range that was stated.
By their numbers in this assay, from the lowest: compound 3; then compounds 2, 4 and 1 (each within the scatter of the next, the first and the last beyond it).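

In this assay, furan-3-yl on an aromatic carbon, meta to a large group, gives a number 5 percentage points lower from compound 1 to compound 4 (within the scatter), so an added aromatic ring on the phenyl of compound 1 does not always lower the read-out beyond the scatter. Compound 3 goes the other way, with a number 27 percentage points lower from compound 1 to compound 3 (beyond the scatter). Nothing shown here accounts for the difference between these two additions. From the compounds shown here alone, whether an amine, a carboxylic acid or a longer chain at the place of the furan-3-yl would keep the read-out remains open, as does whether any group there would raise it.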